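The source may hold more compounds than are shown below. What is called first, only, known or untested is meant among the compounds shown, and "the series" means these compounds.

The series is built on a shared core. Compound 1 `C=CC1=C(C(=O)NCC(C)C)C(c2ccc(F)cc2)OC1` carries an isobutyl group on the amide-type nitrogen, compound 2 `C=CC1=C(C(=O)NC2CCCCC2)C(c2ccc(OC)cc2)OC1` a cyclohexyl group, and compound 3 `C=CC1=C(C(=O)NCC(C)C)C(c2ccc(OC)cc2)OC1` pairs the isobutyl amide of compound 1 with the aryl group of compound 2. In a functional assay on SW480 cells (Homo sapiens) for cytotoxicity, read by MTT assay, with a stated time of 24 h (on this read-out lower numbers stand for stronger inhibition and higher numbers for weaker inhibition), compound 1 returns > 100000 nM, which is a limit of the assay rather than a number. In this assay compound 2 likewise returns > 100000 nM, again a limit of the assay and not a number. Among the measured compounds shown here, compound 2 therefore stands where every value so far stands, at the limit of > 100000 nM in this assay, at which 2 of the 2 values shown sit, and no measured step between compounds is available. The change from compound 2 to compound 3 reads (isobutyl in place of cyclohexyl on an amide-type nitrogen). With both values shown being limits, no direction can be read from the data, and the step that the limit leaves unreadable from compound 2 to compound 3 is expected to stay within the scatter, most probably as a further limit rather than a number. Compound 3 is estimated at 150000 nM in this assay, with a range from 50000 nM to 500000 nM.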

Compound 3, half-maximal inhibitory concentration: > 100000 nM
Compound 3 ended at the assay's limit; the forecaster's own chance of this, stated with the estimate: 80%; the middle value is on the limit's open side.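

In this assay compound 3 gives > 100000 nM, a limit of the assay and not a number, so the steps joining compound 3 to compound 1 and compound 2 cannot be read: the limit of > 100000 nM in this assay, at which 3 of the 3 values shown sit.

The compounds shown leave open whether any group on the amide-type nitrogen or the aromatic carbon gives a readable value.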